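Triazolopyrimidine series: amine side chain and receptor binding

The source may report more compounds than this note shows. Statements on the series, on what has been measured and on what is new or still open speak of the compounds shown alone.

Measured so far:
compound 1 `COCC(COC)Nc1nc(C)nc2c1nnn2-c1ccc(C(C)C)cc1Br` 10.3 nM
compound 2 `CCCCC(CC)Nc1nc(C)nc2c1nnn2-c1ccc(C(C)C)cc1Br` 3.1 nM

In an in vitro assay on 293-EBNA cells for binding affinity to corticotropin-releasing factor receptor 1 (Homo sapiens) (on this read-out higher numbers stand for weaker inhibition and lower numbers for stronger inhibition), compound 2 holds the lowest of the two numbers; its nearest neighbour is compound 1, and the step of a 3.3-fold lower number from compound 1 to compound 2 (0.52 log units; beyond the scatter) is modest but beyond the scatter. Compound 3 `CCC(CO)Nc1nc(C)nc2c1nnn2-c1ccc(C(C)C)cc1Br` is not yet measured. It differs from compound 2 by hydroxy in place of propyl on a saturated chain carbon, two bonds along the chain from a nitrogen on an aromatic ring. Among the compounds with values here, the only step with any bearing is the one from compound 1 to compound 2, where an all-carbon chain in place of one carrying two methoxy groups gave the modest fall noted. The change to compound 3 runs the other way: carbon is removed and a hydroxy group enters. A rise in the number, of roughly the size of that step or somewhat larger, is therefore expected, with compound 3 estimated at 20 nM (range 6 nM to 70 nM), a step of a 6.5-fold higher number from compound 2 to compound 3 (0.81 log units; beyond the scatter) from compound 2.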

Compound 3, inhibition constant: 25.3 nM
Compound 3: middle estimate off by 1.3-fold (0.10 log units), on the low side; low and high end bracket the measured number.
By their numbers in this assay, from the lowest: compound 2; then compound 1; then compound 3.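

In this assay there is an 8.2-fold higher number from compound 2 to compound 3 (0.91 log units; beyond the scatter) when hydroxy replaces propyl, so the number at this place does not hold when the chain is shortened and carries a hydroxy. The oxygen-bearing chains also differ from each other: there is a 2.5-fold higher number from compound 1 to compound 3 (0.39 log units; beyond the scatter) with 1-(hydroxymethyl)propyl in place of 2-methoxy-1-(methoxymethyl)ethyl, so the presence of oxygen in the side chain does not by itself set one level. Of the three side chains, the all-carbon 1-ethylpentyl keeps the lowest number.
No measurement at hand accounts for these shifts.

Propyl leaves and hydroxy enters in a single change, so the effects of the shorter chain and of the hydroxy cannot be told apart here. A 1-ethylpropyl group, or a methoxy or an amine in place of the hydroxy, would separate them.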